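This account rests on a few compounds, and the source may have more. Where it says the series, first, only, none or still open, it means among the compounds named here.

In a functional assay on A2780 cells (Homo sapiens) for antiproliferative activity, read by MTT assay, with a stated time of 48 h (a lower number here means a stronger inhibitor, a higher number a weaker inhibitor), compound 1 (`COc1ccc2c(/C=C/C(=O)c3cc(N)c(OC)c(OC)c3)cn(C)c2c1`) gives 156 nM, compound 2 (`COc1cc(C(=O)/C=C/c2c[nH]c3ccccc23)cc(SC)c1OC`) gives 169 nM and compound 3 (`COc1ccc2c(/C=C/C(=O)c3cc(OC)c(OC)c(SC)c3)cn(C)c2c1`) gives 145 nM, so compound 3 lies within the scatter of both others. Compound 4 (`COc1cc(C(=O)/C=C/c2cn(C)c3ccccc23)cc(SC)c1OC`) differs from compound 3 by hydrogen in place of methoxy on an aromatic carbon. Going by the values given here, no measured step covers this exact change. The only one, a 1.1-fold lower number from compound 1 to compound 3 (0.03 log units; within the scatter), concerns a different group and stays within the scatter. Compound 2 also has hydrogen at that place and gives 169 nM, within the scatter of compound 3, although it differs elsewhere too. The expected step in this assay is therefore none beyond the scatter, estimated as a 1.0-fold higher number from compound 3 to compound 4 (0.01 log units; within the scatter). For compound 4 the estimated value is 150 nM, with an expected range of 65 nM to 350 nM.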

Compound 4, half-maximal inhibitory concentration: 193 nM
The estimate for compound 4 lay 1.3-fold (0.11 log units) below the measured number; the range from low to high includes it.
By their numbers in this assay, from the lowest: compounds 3, 1, 2 and 4 (each within the scatter of the next).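

The methoxy on this aromatic carbon of the fused system can give way to hydrogen with only a 1.3-fold higher number from compound 3 to compound 4 (0.12 log units; within the scatter) in this assay, so at this position the group's loss stays within the scatter. Methyl in place of hydrogen on the aromatic nitrogen, a change the earlier compounds did not isolate, likewise gives only a 1.1-fold higher number from compound 2 to compound 4 (0.06 log units; within the scatter). No measurement here offers a reason for either step. Still open, going by these compounds, is whether a different group at this carbon, such as a carboxylic acid or a longer chain like butoxy, would shift the number beyond the scatter.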